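Moving the methoxy group: compound 3 to compound 4

This account rests on a few compounds, and the source may have more. Where it says the series, first, only, none or still open, it means among the compounds named here.

Of the compounds shown here, three with a shared core have been measured in an ADME assay on HEL cells (Homo sapiens) for cytotoxicity, with a stated time of 3 days; on this read-out lower numbers stand for higher toxicity in this test and higher numbers for lower toxicity in this test. Compound 1 `Cc1cc(-c2ccccc2)c2ncc(CSCCc3ccccc3)n2c1` gives 20 ug/mL. Compound 2 `Cc1cc(-c2ccsc2)c2ncc(CSCCc3ccccc3)n2c1` gives 100 ug/mL, and compound 3 `COc1cccc(-c2cc(C)cn3c(CSCCc4ccccc4)cnc23)c1` gives 100 ug/mL. The two single-point steps from compound 1 are a 5.0-fold higher number from compound 1 to compound 2 (0.70 log units; beyond the scatter) and a 5.0-fold higher number from compound 1 to compound 3 (0.70 log units; beyond the scatter), whereas no change at the digits printed from compound 2 to compound 3 (within the scatter). Compound 3 thus stands level with compound 2 at the digits given, the two together having the highest numbers of the three, and furthest from compound 1.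

Compound 4 `COc1ccc(-c2cc(C)cn3c(CSCCc4ccccc4)cnc23)cc1` differs from compound 3 by 4-methoxyphenyl in place of 3-methoxyphenyl on an aromatic carbon. Within the data shown here, no measured step exchanges one methoxyphenyl for another; the steps that bear on this ring are a 5.0-fold higher number from compound 1 to compound 3 (0.70 log units; beyond the scatter), which brings in the methoxy group, and no change at the digits printed from compound 2 to compound 3 (within the scatter), which replaces a different aromatic ring with it. Neither gives a reason to expect a shift beyond the scatter in this assay for compound 4, so a step of about no change at the digits printed from compound 3 to compound 4 (within the scatter) is expected. Compound 4 is therefore estimated at 100 ug/mL, with a range from 40 ug/mL to 200 ug/mL.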

Compound 4, minimum cytotoxic concentration: 20 ug/mL
Compound 4: middle estimate off by 5.0-fold (0.70 log units), on the high side; the whole stated range lies above it.
By their numbers in this assay, from the lowest: compounds 1 and 4 (each within the scatter of the next); then compounds 2 and 3 (each within the scatter of the next).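

In this assay the place of the methoxy group on the phenyl ring counts, with a 5.0-fold lower number from compound 3 to compound 4 (0.70 log units; beyond the scatter), so the higher number seen earlier on adding methoxy holds for 3-methoxyphenyl and not for methoxy as such. At this ring position, 4-methoxyphenyl also shows a 5.0-fold lower number from compound 2 to compound 4 (0.70 log units; beyond the scatter), while methoxy in place of hydrogen in this arrangement gives no change at the digits printed from compound 1 to compound 4 (within the scatter). Nothing available here accounts for the difference between the two methoxyphenyl groups.

From the compounds shown here alone, it remains open whether a hydroxy group, an amine or a fluorine in place of the methoxy would follow the same dependence on where it sits on the phenyl ring. Going by these compounds, it is also open whether the gap between 3-methoxyphenyl and 4-methoxyphenyl would persist with a longer chain in place of the phenethyl thioether arm.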